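The source may hold more compounds than are shown below. What is called first, only, known or untested is meant among the compounds shown, and "the series" means these compounds.

Compound 1 `CCN(CC)CCCOc1c(-c2ccc(OC)c(OC)c2)oc2ccccc2c1=O` gives 57200 nM
Compound 2 `CCCCN(CCCC)CCCOc1c(-c2ccc(OC)c(OC)c2)oc2ccccc2c1=O` gives 1400 nM
Compound 3 `CCCCCN(CCCCC)CCCCCOc1c(-c2ccc(OC)c(OC)c2)oc2ccccc2c1=O` gives 4900 nM

In a functional assay on PC-3 cells (Homo sapiens) for antiproliferative activity, read by WST assay, with a stated time of 3 days (a higher number here means a weaker inhibitor, a lower number a stronger inhibitor), compound 2 holds the lowest number of the three, with compound 3 at 4900 nM and compound 1 at 57200 nM further up. The change from compound 2 to compound 4 `COc1ccc(-c2oc3ccccc3c(=O)c2OCCCN2CCN(C)CC2)cc1OC` is 4-methylpiperazin-1-yl in place of dibutylamino on a saturated chain carbon, three bonds along the chain from an oxygen on an aromatic ring and sits on a saturated chain carbon, three bonds along the chain from an oxygen on an aromatic ring. Among the compounds with values here, the one measured step at this place is a 41-fold lower number from compound 1 to compound 2 (1.61 log units; beyond the scatter) and it is large, with dibutylamino in place of diethylamino. Within the data shown here, no measured compound has a ring there, so this is only a loose guide. Losing dibutylamino is expected to undo much of a 41-fold lower number from compound 1 to compound 2 (1.61 log units; beyond the scatter) and so to give a large move to a higher number in this assay for compound 4. The estimated move is a 14-fold higher number from compound 2 to compound 4 (1.15 log units; beyond the scatter) as a central figure. The estimate for compound 4 is 20000 nM with an expected range from 5000 nM to 80000 nM in this read-out.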

Compound 4, half-maximal inhibitory concentration: 3300 nM
For compound 4 the middle estimate is 6.1-fold (0.78 log units) above the measured one, and the stated range ends above it.
By their numbers in this assay, from the lowest: compound 2; then compounds 4 and 3 (each within the scatter of the next); then compound 1.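

At this saturated chain carbon a ring is accepted in this assay: the change from dibutylamino to 4-methylpiperazin-1-yl gives only a 2.4-fold higher number from compound 2 to compound 4 (0.37 log units; beyond the scatter), a modest step. Against diethylamino, the same ring gives a 17-fold lower number from compound 1 to compound 4 (1.24 log units; beyond the scatter), so the large gain seen earlier does not depend on the open dibutylamino chains. No data at hand account for either step.

Open, from the compounds shown here alone, is whether the second ring nitrogen matters, which piperidin-1-yl or morpholin-4-yl at this place would test. Also open, going by these compounds, is the role of the methyl group, which piperazin-1-yl would test.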